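The source may report more compounds than this note shows. Statements on the series, on what has been measured and on what is new or still open speak of the compounds shown alone.

Of the compounds shown here, two have so far been measured in a functional assay on L1210 cells (Mus musculus) for antiproliferative activity; on this read-out lower numbers stand for lower potency and higher numbers for higher potency (the scale is a negative logarithm). Compound 1 `CCOC(=O)c1ccc(/N=N/N(C)CC(C)C)cc1` gives 2.8 in this assay. Compound 2 `C=CCN(C)/N=N/c1ccccc1C(N)=O` gives 3.43 in this assay, the higher of the two numbers, and its gap to compound 1 lies beyond the usual scatter of such measurements. Among the compounds with values here, the two compounds differ in more than one place at once, so their values show only that compound 2 is the more potent of the pair and nothing about any single change.

Compound 3 `CCCN(C)/N=N/c1ccccc1C(N)=O` has not yet been measured. It differs from compound 2 in one place: ethyl in place of vinyl on a saturated chain carbon bound to an amine nitrogen. The count of heavy atoms is unchanged; the difference lies in the double bond outside aromatic rings that leaves. Within the data shown here, no measured pair isolates this kind of change, so no measured step can guide the expectation, and it rests on the structural change alone. The author expects the step in this assay to stay within the scatter, with no clear direction: a number 0.03 log units lower from compound 2 to compound 3 (within the scatter). Compound 3 is therefore estimated at 3.4 in this assay, with a likely range from 2.9 to 3.9.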

Compound 3, logarithm of the reciprocal of the active concentration, log(1/C): 3.26
Compound 3: the middle estimate sits 0.14 log units above what was measured; the measured number falls inside the stated range.
By their numbers in this assay, from the lowest: compound 1; then compounds 3 and 2 (each within the scatter of the next).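

Read as a single change, ethyl in place of vinyl on a saturated chain carbon bound to an amine nitrogen gives a number 0.17 log units lower from compound 2 to compound 3 (within the scatter) in this assay, the first step in this series that isolates one difference. Within the data shown here, at this place, then, the double bond outside aromatic rings can be lost while the number stays within the scatter of the one for compound 2, so in this pair allyl and propyl cannot be told apart by this read-out. No measurement is available that would explain this step or the closeness of the two values.

Still open, as far as these compounds go, is whether a longer chain such as butyl, or a chain carrying a hydroxyl group, an amine or a carboxylic acid, would stay as close to compound 2 at this place, since a single pair says nothing about how much room for change the position allows. Also open, from the compounds shown here alone, is whether the exchange of allyl for propyl would give a step of similar size on another core, such as the core of compound 1.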